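This account rests on a few compounds, and the source may have more. Where it says the series, first, only, none or still open, it means among the compounds named here.

Among the compounds with values here, compound 2 `Cc1cccnc1N1CCN(C(=O)Nc2ccc(C(C)C)cc2)CC1` gives the lowest of the two numbers so far in a functional assay on HEK293 cells for antagonist activity at transient receptor potential cation channel subfamily V member 1 (Rattus norvegicus) (a lower number here means a stronger inhibitor, a higher number a weaker inhibitor), at 173 nM. Its nearest neighbour is compound 1 `CC(C)c1ccc(NC(=O)N2CCN(c3ncccc3[N+](=O)[O-])CC2)cc1`, which in this assay gives 245 nM; that step, a 1.4-fold lower number from compound 1 to compound 2 (0.15 log units; within the scatter), concerns a different position and lies within the scatter. Compound 3 `CCc1cccnc1N1CCN(C(=O)Nc2ccc(C(C)C)cc2)CC1` differs from compound 2 by methyl in place of hydrogen on a saturated chain carbon bound to an aromatic carbon, read more widely as 3-methylpyridin-2-yl becoming 3-ethylpyridin-2-yl. Within the data shown here, no measured step bears directly on this change, so nothing here points beyond the scatter. Compound 3 is therefore expected to give about 170 nM, within 70 nM to 420 nM. This expected step of a 1.0-fold lower number from compound 2 to compound 3 (0.01 log units; within the scatter) would stay within the scatter.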

Compound 3, half-maximal inhibitory concentration: 828 nM
For compound 3 the middle estimate is 4.9-fold (0.69 log units) below the measured one, outside the stated range (above it).
By their numbers in this assay, from the lowest: compounds 2 and 1 (each within the scatter of the next); then compound 3.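

In this assay, lengthening methyl to ethyl on this pyridine moves the result beyond the scatter (a 4.8-fold higher number from compound 2 to compound 3 (0.68 log units; beyond the scatter)), although methyl and nitro could not be told apart here. Compound 3 also separates from the nitro compound (a 3.4-fold higher number from compound 1 to compound 3 (0.53 log units; beyond the scatter)), so one added carbon at this place is enough to give a weaker inhibitor. No evidence here explains why this single carbon matters.

Going by these compounds, what a propyl chain, a chlorine atom or an amine at this place would give remains open. So does whether a longer chain would weaken inhibition further.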